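Benzamide variation on the shared core, aryl swap

The source may report more compounds than this note shows. Statements on the series, on what has been measured and on what is new or still open speak of the compounds shown alone.

Compound 1 `O=C(Nc1cc(-c2ccccc2)nn1-c1ccccc1)c1ccccc1Cl` gives 2500 nM in an assay on CHO cells with metabotropic glutamate receptor 5 (Homo sapiens) as the target; on this read-out higher numbers stand for an effect only at larger amounts of compound and lower numbers for an effect already at smaller amounts. Compound 2 `O=C(Nc1cc(-c2ccccc2)nn1-c1ccccc1)c1cccc(F)c1` gives 20 nM in this assay and stands at the lowest of the two numbers, its nearest neighbour being compound 1. Among the measured compounds shown here, the one measured step, a 130-fold lower number from compound 1 to compound 2 (2.10 log units; beyond the scatter), was large. Compound 3 `O=C(Nc1cc(-c2ccccc2)nn1-c1ccccc1)c1ccc(C(F)(F)F)cc1` differs from compound 2 by 4-(trifluoromethyl)phenyl in place of 3-fluorophenyl on a carbonyl carbon. For the measured compounds named here, no measured step covers this change, and the single step known shows only that this aryl group can move the read-out strongly, so a shift beyond the scatter in either direction is plausible. Compound 3 is expected near 100 nM (range 15 nM to 700 nM). The expected step is a 5.0-fold higher number from compound 2 to compound 3 (0.70 log units; beyond the scatter).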

Compound 3, half-maximal effective concentration: 19 nM
For compound 3 the middle estimate is 5.3-fold (0.72 log units) above the measured one; measured number inside the range.
By their numbers in this assay, from the lowest: compounds 3 and 2 (each within the scatter of the next); then compound 1.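

In this assay, 4-(trifluoromethyl)phenyl in place of 3-fluorophenyl on a carbonyl carbon gives a 1.1-fold lower number from compound 2 to compound 3 (0.02 log units; within the scatter), so two differently substituted aryl groups are interchangeable at this position on this read-out. The same group in place of 2-chlorophenyl gives a 130-fold lower number from compound 1 to compound 3 (2.12 log units; beyond the scatter), leaving compound 1 apart from both other compounds. No data bearing on the reason for either step are at hand.

Going by these compounds, whether 2-fluorophenyl would read like 2-chlorophenyl stays open. So does the read-out with an amine or a carboxylic acid in place of these aryl substituents.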